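Phenyl in place of iodo on the shared core

The compounds below may be only part of what the source reports. "The series", "measured", "known", "first", "only" and "open" are said of these compounds alone.

Measured compounds, all in an ADME assay on BJ cells (Homo sapiens), read by MTT assay, with a stated time of 72 h; a lower number here means a stronger inhibitor, a higher number a weaker inhibitor:
Compound 1, `Nc1nc(N)c2c(-c3cc4ccccc4o3)cn([C@@H]3O[C@H](CO)[C@@H](O)[C@H]3O)c2n1`, gives > 100000 nM; this is a limit of the assay, not a number.
Compound 2, `COc1ncnc2c1c(I)cn2[C@@H]1O[C@H](CO)[C@@H](O)[C@H]1O`, gives 91000 nM.
Compound 3, `Nc1nc2c(c(-c3ccccc3)cn2[C@@H]2O[C@H](CO)[C@@H](O)[C@H]2O)c(=O)[nH]1`, gives > 100000 nM; this too is a limit, not a number.

Among the measured compounds shown here, compound 2 is the only one of the three with a number in this assay; the other two values are limits (the limit of > 100000 nM in this assay, at which 2 of the 3 values shown sit), so no step between measured compounds can be drawn and compound 2 cannot be ranked against them. The unmeasured compound 4, `COc1ncnc2c1c(-c1ccccc1)cn2[C@@H]1O[C@H](CO)[C@@H](O)[C@H]1O`, differs from compound 2 in one place: phenyl in place of iodo on an aromatic carbon. For the measured compounds named here, no measured pair carries this change. Going by the values given here, compound 3 also bears a phenyl on its core and compound 1 a benzofuranyl, and both sit at the limit, while compound 2 with iodo is the only one that returned a number; this leaves the direction of the step open but points toward weakness. In this assay the expected step is small, toward weaker inhibition or none beyond the scatter: a 1.3-fold higher number from compound 2 to compound 4 (0.12 log units; within the scatter). Compound 4 is therefore estimated at about 120000 nM, in the range 40000 nM to 400000 nM, with a fair chance that only a limit is reported.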

Compound 4, half-maximal inhibitory concentration: > 100000 nM
Compound 4 gave a limit, no number; the forecaster's own chance of this, stated with the estimate: 55%; the middle value lies beyond the limit too.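

In this assay compound 4 gives > 100000 nM, which is a limit and not a number. Among the compounds shown here, this gives the first one-place step at this aromatic carbon, two ring bonds from the ring nitrogen: phenyl in place of iodo gives an at least 1.0-fold higher number from compound 2 to compound 4 (0.04 log units; that floor lies within the scatter), so the change is bounded on one side only, and neither a real loss nor the absence of one is established. With iodo already close to the limit of the assay, the step has little room to be read in full: the limit of > 100000 nM in this assay, at which 3 of the 4 values shown sit.

The true size of the step stays open, since only a limit stands for the phenyl compound, and the compounds shown do not tell whether any group on this carbon can bring the number well below that of compound 2 in this assay. An amine, a carboxylic acid or a short alkyl chain at this place, on the core shared by compound 2 and compound 4, would test whether this position can move the number at all.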